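A few compounds are considered here, and "the series" means these few. Any claim that something is new, unique, unknown or untested is made for them only; others in the source may bear on it.

In a functional assay on cells (Mast cell, Rattus norvegicus, strain Wistar) for activation, read by fluorescence, with a stated time of 15 min (a higher number here means that more compound is needed for the effect, a lower number that less compound is needed), compound 1 `CCCCCCCCCCCCCCCCCC(=O)OC[C@@H](COP(=O)(O)OC[C@H](N)C(=O)O)OC` gives 5000 nM and compound 2 `CCCCCCCCCCCCCCCCCC(=O)N(C)C[C@@H](O)COP(=O)(O)OC[C@H](N)C(=O)O` gives 10000 nM, two values within the usual scatter of each other. Compound 3 `CCCCCCCCCCCCCCCCCC(=O)OC[C@@H](O)COP(=O)(O)OC[C@H](N)C(=O)OC` gives > 10000 nM, which is a limit of the assay and not a number. On these data alone, compound 3 therefore has no exact position on this scale, and any comparison with it stays open on one side.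

Compound 4 `CCCCCCCCCCCCCCCCCC(=O)OC[C@@H](O)COP(=O)(O)O[C@@H]1CCN[C@H]1C(=O)O` has not yet been measured. The change from compound 3 is this: a group of 8 heavy atoms (5 carbon, 1 nitrogen, 2 oxygen; one five-membered non-aromatic ring with 1 hetero atom) in place of a group of 7 heavy atoms (4 carbon, 1 nitrogen, 2 oxygen; no ring), on an oxygen. The 2-amino-2-(methoxycarbonyl)ethyl group leaves, and a group with one five-membered non-aromatic ring enters, on an oxygen whose other neighbour is phosphorus.

Within the data shown here, no measured pair shows this change directly, so the only guide is that compound 4, like compound 1 at 5000 nM and compound 2 at 10000 nM, lacks the methoxycarbonyl group. A small move towards a lower number is expected, and it may not exceed the scatter, as the estimated at least 1.4-fold lower number from compound 3 to compound 4 (0.15 log units; that floor lies within the scatter) shows. For compound 4 the estimated value is 7000 nM, with an expected range from 1500 nM to 30000 nM.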

Compound 4, half-maximal effective concentration: > 10000 nM
Compound 4 ended at the assay's limit (the forecaster's own chance of this, stated with the estimate: 40%); at least 1.4-fold (0.15 log units) between middle value and limit.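

In this assay compound 4 gives > 10000 nM, which is a limit of the assay and not a number. Among these compounds, compound 3 also stands at a limit, and no step from compound 3 to compound 4 can be read. The compounds shown leave open whether replacing the 2-amino-2-(methoxycarbonyl)ethyl group with the five-membered ring group changes the number at all.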